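This account rests on a few compounds, and the source may have more. Where it says the series, first, only, none or still open, it means among the compounds named here.

Measured so far in a functional assay on MRC5 cells (Homo sapiens); on this read-out lower numbers stand for higher toxicity in this test and higher numbers for lower toxicity in this test:
compound 1 `COc1ccc(CN2c3ccccc3C(=O)N(Cc3ccccc3)S2(=O)=O)cc1` gives 61000 nM
compound 2 `O=C1c2ccccc2N(Cc2cccc3ccccc23)S(=O)(=O)N1Cc1ccccc1` gives > 58000 nM (a limit of the assay)

Compound 2 stands at the limit in this assay, not at a number: its value of > 58000 nM is a limit, and this is noted as the limit of > 58000 nM in this assay, at which 1 of the 2 values shown sits. Compound 1, by contrast, gives a number, 61000 nM in this assay. Among the measured compounds shown here, the one measured step, a step that the limit leaves unreadable from compound 1 to compound 2, is therefore unreadable in size, because the limit of > 58000 nM in this assay, at which 1 of the 2 values shown sits, leaves only a bound.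

The next compound, compound 3 `CC(C)CN1c2ccccc2C(=O)N(Cc2ccccc2)S1(=O)=O`, is not yet measured in this assay. Its change from compound 2 is isopropyl in place of naphthalen-1-yl on a saturated chain carbon bound to a sulfonamide nitrogen in a ring. For the measured compounds named here, no measured step shares this change; the single step available, a step that the limit leaves unreadable from compound 1 to compound 2, bears on it only in that both replace the group on the saturated chain carbon bound to the sulfonamide nitrogen in the ring, and that step could not be sized. With two compounds sitting at or near the same high end of this assay, no direction can be read for compound 3, and the step expected, a step that the limit leaves unreadable from compound 2 to compound 3, is estimated as none beyond the scatter. Compound 3 is expected at about 65000 nM, in the range 30000 nM to 150000 nM, with a fair chance that only a limit is returned.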

Compound 3, half-maximal cytotoxic concentration: 72000 nM
Compound 3: middle estimate off by 1.1-fold (0.04 log units), on the low side, within the range that was stated.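

In this assay, isopropyl in place of 4-methoxyphenyl on a saturated chain carbon bound to a sulfonamide nitrogen in a ring is a 1.2-fold higher number from compound 1 to compound 3 (0.07 log units; within the scatter). Among the compounds shown here, this is the first step at this position that can be sized, and it shows that a group with no ring and a group with an aromatic ring can sit within the scatter of each other here, which holds for compound 1 and compound 3 only. Compound 2 gives only a limit, and the steps to and from it cannot be read: the limit of > 58000 nM in this assay, at which 1 of the 3 values shown sits.

As far as these compounds go, whether the naphthalen-1-yl group of compound 2 truly matches the other two groups in this assay stays open, since its limit gives no number to set beside them. Also open, from the compounds shown here alone, is whether a group of another kind on the same saturated chain carbon, such as an amine, a carboxylic acid or a longer chain, would give a value beyond the scatter of those of compound 1 and compound 3.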